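The compounds below may be only part of what the source reports. "The series", "measured", "known", "first", "only" and "open" are said of these compounds alone.

Compound 1 `OC[C@H]1O[C@@H](OCCc2ccc(O)c(Br)c2)[C@H](O)[C@@H](O)[C@@H]1O` is the reference point of this comparison. In a functional assay, with a stated time of 30 min (on this read-out higher numbers stand for weaker inhibition and lower numbers for stronger inhibition), compound 1 gives > 100000 nM, which is a limit of the assay and not a number. Compound 2 `OC[C@H]1O[C@@H](OCCc2ccc(O)c(Br)c2)[C@H](O)[C@@H](O)[C@H]1O` is its stereoisomer, and the comparison between them rests on (the fact that compounds 1 and 2 differ only in the configuration as drawn). In this assay compound 2 gives > 100000 nM, again a limit. Compound 3 `OC[C@H]1O[C@@H](OCCc2cc(Br)c(O)c(Br)c2)[C@H](O)[C@@H](O)[C@@H]1O` carries an additional bromo group. In this assay compound 3 gives > 100000 nM, also a limit. The step that the two limits leave unreadable from compound 1 to compound 2 and the step that the two limits leave unreadable from compound 1 to compound 3 are therefore unreadable because of the limit of > 100000 nM in this assay, at which 3 of the 3 values shown sit, so neither the stereochemical change nor the added bromo group yields a direction or a size.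

Compound 4 `CCOc1cc(CCO[C@@H]2O[C@H](CO)[C@@H](O)[C@H](O)[C@H]2O)ccc1O` has not yet been measured. It differs from compound 1 in one place: ethoxy in place of bromo on an aromatic carbon. For the measured compounds named here, no measured step bears readably on this change, and the three limits show only that compound 1 itself sits at the limit. The step from compound 1 to compound 4 is expected to be a step that the limit leaves unreadable from compound 1 to compound 4, that is, no movement that can be read beyond the scatter. Compound 4 is accordingly expected to give 150000 nM in this assay, with a range from 30000 nM to 1000000 nM, and most probably to be reported once more as a limit.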

Compound 4, half-maximal inhibitory concentration: 66800 nM
Estimate against measurement, compound 4: 2.2-fold (0.35 log units) above; low and high end bracket the measured number.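

Compound 4 is the first compound shown in this assay to give a number, 66800 nM rather than a limit, so this position, ortho to a hydroxy group, now has one readable value. Ethoxy in place of bromo on this aromatic carbon gives an at least 1.4-fold lower number from compound 1 to compound 4 (0.17 log units; that floor lies within the scatter) and this is only a floor, so the true step may be larger or may lie no further than the scatter. The change can be read only from one side, and its full size stays unknown, because one end of the step is a limit: the limit of > 100000 nM in this assay, at which 3 of the 4 values shown sit.

The compounds shown leave open whether the number for compound 4 is particular to ethoxy, as a methoxy, a longer chain such as propoxy or a plain hydroxy on the same aromatic carbon does not appear among them. They also leave open whether the stereochemical change of compound 2, or the additional bromo group of compound 3, would register once ethoxy stands in place of bromo on the core of compound 1.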